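The source may report more compounds than this note shows. Statements on the series, on what has been measured and on what is new or still open speak of the compounds shown alone.

Working notes on the series. Compound 1 `COc1ccc(SCc2ccc(C(=O)Nc3ccccc3N)cc2)cc1` gives 90.1% in a functional assay on HCT-116 cells (Homo sapiens) for inhibition, read by CCK-8 assay, with a stated time of 72 h, tested at 8 uM; on this read-out higher numbers stand for more inhibition of growth at the one concentration tested and lower numbers for less inhibition of growth. Compound 2 `Nc1ccccc1NC(=O)c1ccc(CSc2cccc(F)c2)cc1` gives 81.4% in this assay, while compound 3 `CC(C)(C)c1ccc(SCc2ccc(C(=O)Nc3ccccc3N)cc2)cc1` gives 60.5% in this assay, the lowest of the three numbers. The step of a number 29.6 percentage points lower from compound 1 to compound 3 (beyond the scatter) lies beyond the scatter, whereas the step of a number 8.7 percentage points lower from compound 1 to compound 2 (within the scatter) stays within it. Compound 4 `Nc1ccccc1NC(=O)c1ccc(CSc2ccc(F)cc2)cc1` differs from compound 3 by fluoro in place of tert-butyl on an aromatic carbon. Among the compounds with values here, both measured steps bear on this change: removing tert-butyl undoes the only step that lowered the numbers beyond the scatter, and a fluoro is already present in compound 2. An upward step a number 21.5 percentage points higher from compound 3 to compound 4 (beyond the scatter) is therefore expected in this assay, because compound 2 gives 81.4%. Compound 4 is estimated at 82%, with a range from 65% to 95%.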

Compound 4, percent growth inhibition at one concentration: 90.6%
The estimate for compound 4 lay 8.6 percentage points below the measured number; the measured number falls inside the stated range.
By their numbers in this assay, from the lowest: compound 3; then compounds 2, 1 and 4 (each within the scatter of the next).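

At this aromatic carbon, para to a large group, tert-butyl alone stands apart: the change to fluoro gives a number 30.1 percentage points higher from compound 3 to compound 4 (beyond the scatter) in this assay, while methoxy and fluoro cannot be told apart, with a number 0.5 percentage points higher from compound 1 to compound 4 (within the scatter). Moving the fluorine on the sulfur-bound ring, 4-fluorophenyl in place of 3-fluorophenyl, gives a number 9.2 percentage points higher from compound 2 to compound 4 (within the scatter), so no preference between these two is shown. Nothing available explains the tert-butyl result.

As far as these compounds go, whether an amine or a carboxylic acid at this position would match fluoro and methoxy or fall with tert-butyl remains open. Also open, from the compounds shown here alone, is whether a full concentration series would separate compound 1 from compound 4.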